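Extending the methyl to ethyl on the benzamide of compound 1

A few compounds are considered here, and "the series" means these few. Any claim that something is new, unique, unknown or untested is made for them only; others in the source may bear on it.

Measured compounds:
compound 1 `CCN1CCN(c2cc(C)c3cc(NC(=O)c4ccc(C)cc4)ccc3n2)CC1` with 6740 nM
compound 2 `CCN1CCN(c2cc(C)c3cc(NC(=O)c4ccc(Br)cc4)ccc3n2)CC1` with 5940 nM
compound 3 `CCc1ccccc1C(=O)Nc1ccc2nc(N3CCN(CC)CC3)cc(C)c2c1` with 15800 nM

In a functional assay on MCF7 cells (Homo sapiens) for antiproliferative activity, read by MTT assay, with a stated time of 72 h (on this read-out higher numbers stand for weaker inhibition and lower numbers for stronger inhibition), compound 1 gives 6740 nM. On the numbers available, compound 1 sits second highest of the three; compound 2 lies nearest, with a 1.1-fold lower number from compound 1 to compound 2 (0.05 log units; within the scatter), and compound 3 lies furthest, with a 2.3-fold higher number from compound 1 to compound 3 (0.37 log units; beyond the scatter). The step from compound 2 to compound 3 is a 2.7-fold higher number from compound 2 to compound 3 (0.42 log units; beyond the scatter).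

The unmeasured compound 4 `CCc1ccc(C(=O)Nc2ccc3nc(N4CCN(CC)CC4)cc(C)c3c2)cc1` differs from compound 1 by methyl in place of hydrogen on a saturated chain carbon bound to an aromatic carbon. Within the data shown here, the measured step that bears most closely on it is the one from compound 1 to compound 2, where a bromo in place of methyl on an aromatic carbon gave a number within the scatter: a change at that position of the 4-methylphenyl ring left the read-out essentially unmoved. The steps to compound 3 concern a 2-ethylphenyl in place of the 4-methylphenyl, a different change, and gave modest rises; they do not speak directly to an ethyl at the position held by the methyl in compound 1. The author therefore expects no step beyond the scatter in this assay for compound 4, with an estimated step of a 1.0-fold lower number from compound 1 to compound 4 (0.02 log units; within the scatter). Compound 4 is estimated at 6500 nM, within a range of 3000 nM to 14000 nM.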

Compound 4, half-maximal inhibitory concentration: 3060 nM
Beside the measured number, compound 4's estimate is 2.1-fold (0.33 log units) above it, and the stated range covers the measured number.
By their numbers in this assay, from the lowest: compounds 4, 2 and 1 (each within the scatter of the next, the first and the last beyond it); then compound 3.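

In this assay, lengthening the methyl of compound 1 to an ethyl moves the read-out beyond the scatter, with a 2.2-fold lower number from compound 1 to compound 4 (0.34 log units; beyond the scatter), whereas bromo in place of that methyl had left it within the scatter; the position therefore responds to a change after all, and a single added carbon is enough to show it. Where the ethyl stands also counts, since 4-ethylphenyl in place of 2-ethylphenyl gives a 5.2-fold lower number from compound 3 to compound 4 (0.71 log units; beyond the scatter), the widest step among these compounds. Ethyl and bromo at this place cannot be told apart, with a 1.9-fold lower number from compound 2 to compound 4 (0.29 log units; within the scatter), and nothing available here accounts for any of these steps.

From the compounds shown here alone, whether a longer chain such as propyl would carry the trend further or reverse it remains open, as does the effect of a hydroxyl or an amine on the saturated chain carbon bound to the aromatic carbon. Going by these compounds, the methyl to ethyl step also rests on a single pair of compounds in this assay, so whether it holds on other cells or with other groups on the shared core is unknown.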